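This account rests on a few compounds, and the source may have more. Where it says the series, first, only, none or still open, it means among the compounds named here.

In an ADME assay on microsomes from liver (Mus musculus) for metabolic stability (a higher number here means that the compound lasts longer, a lower number that the compound disappears faster), compound 2 `NS(=O)(=O)CC(=O)NCCSc1nonc1/C(=N/O)Nc1cccc(Cl)c1` gives 1.26 h. Among the compounds with values here, the only other measured compound, compound 1 `NS(=O)(=O)CC(=O)NCCSc1nonc1/C(=N/O)Nc1cccc(C(F)F)c1`, gives 1.5 h in this assay, and the step of a 1.2-fold lower number from compound 1 to compound 2 (0.08 log units; within the scatter) lies within the scatter, so the two numbers cannot be told apart, even though the number for compound 2 is the smaller of the two as written.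

Compound 3 `N#Cc1cc(N/C(=N\O)c2nonc2SCCNC(=O)CS(N)(=O)=O)ccc1F` is made from compound 2 by the change (3-cyano-4-fluorophenyl in place of 3-chlorophenyl on an amine nitrogen). Within the data shown here, the single measured step, a 1.2-fold lower number from compound 1 to compound 2 (0.08 log units; within the scatter), swaps one group on the same aromatic ring and moved the number hardly at all, so the precedent points to a change on this ring leaving the half-life about where it is. The step from compound 2 to compound 3 is therefore expected to be small, a 1.0-fold higher number from compound 2 to compound 3 (0.01 log units; within the scatter), with no direction beyond the scatter. For compound 3 the half-life is estimated at 1.3 h, within a range of 0.6 h to 2.8 h.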

Compound 3, half-life: 2.38 h
Compound 3: middle estimate off by 1.8-fold (0.26 log units), on the low side, within the range that was stated.
By their numbers in this assay, from the lowest: compounds 2, 1 and 3 (each within the scatter of the next).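

Within the data shown here, compound 3 carries two groups on its ring, a fluorine and a nitrile, where the earlier compounds each carry one, so this is a larger change at the amine nitrogen than the swap seen before. Even so, the data give a 1.9-fold higher number from compound 2 to compound 3 (0.28 log units; within the scatter) and a 1.6-fold higher number from compound 1 to compound 3 (0.20 log units; within the scatter) in this assay, so the 3-cyano-4-fluorophenyl ring takes the half-life to no place that can be told apart from either earlier compound. Nothing measured here explains why the three numbers fall where they do.

As far as these compounds go, with only substituted phenyl rings at this place and the rest of the molecule unchanged, it remains open whether a 3-cyanophenyl ring, with the nitrile alone, would read the same as compound 3. From the compounds shown here alone, whether a cyclohexyl ring or a carboxylic acid on the ring would move the half-life beyond the scatter also remains open.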